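Swapping the Ring-Nitrogen Acyl Group for a Sulfonyl

The compounds below may be only part of what the source reports. "The series", "measured", "known", "first", "only" and "open" are said of these compounds alone.

Compound 3 `CN(C)c1ccc(C2CC(c3ccc(-n4cncn4)cc3)=NN2C(=O)c2cc(Cl)cc(Cl)c2)cc1` gives 5.3% in a functional assay on HCC1806 cells (Homo sapiens) for inhibition, read by sulforhodamine B assay, tested at 10 uM (a higher number here means more inhibition at the concentration tested (going by the name of the read-out), a lower number less inhibition), the lowest of the three numbers on hand. Going by the values given here, compound 1 `CN(C)c1ccc(C2CC(c3ccc(-n4cncn4)cc3)=NN2)cc1` gives 6.8%, and the single measured step, a number 1.5 percentage points lower from compound 1 to compound 3 (within the scatter), lies within the scatter. Compound 2 `CN1CCN(c2ccc(C3=NN(S(=O)(=O)c4ccc(OC(F)(F)F)cc4)C(c4ccc(N(C)C)cc4)C3)cc2)CC1` also carries a sulfonyl on an amine nitrogen in a ring but differs from compound 3 in several places. In this assay compound 2 gives 70.8%. Compound 4 `Cc1ccc(S(=O)(=O)N2N=C(c3ccc(-n4cncn4)cc3)CC2c2ccc(N(C)C)cc2)cc1` differs from compound 3 by (4-methylphenyl)sulfonyl in place of (3,5-dichlorophenyl)carbonyl on an amine nitrogen in a ring. Among the compounds with values here, no measured step covers this exact change; the one known step concerns a different group and was flat, while compound 2 only hints that a sulfonyl-bearing compound can inhibit strongly. The expected step of a number 24.7 percentage points higher from compound 3 to compound 4 (beyond the scatter) is therefore uncertain and leans upward. Compound 4 is estimated at 30%, within 5% to 70%.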

Compound 4, a percentage reported as inhibition, at one concentration (the size of the read-out at that concentration, not a potency): 27.7%
The estimate for compound 4 lay 2.3 percentage points above the measured number, and the stated range covers the measured number.
By their numbers in this assay, from the lowest: compounds 3 and 1 (each within the scatter of the next); then compound 4; then compound 2.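

At this ring nitrogen the attached group can change the outcome in this assay: a number 22.4 percentage points higher from compound 3 to compound 4 (beyond the scatter), and a number 20.9 percentage points higher from compound 1 to compound 4 (beyond the scatter). The earlier step from hydrogen to (3,5-dichlorophenyl)carbonyl lay within the scatter, so only the (4-methylphenyl)sulfonyl group shows a modest rise over hydrogen. No supporting data explain this rise.

On these data alone, this change replaces both the carbonyl link and the substituents on the benzene ring, so the source of the rise remains open. A (4-methylphenyl)carbonyl or (3,5-dichlorophenyl)sulfonyl group on the same nitrogen would separate those two parts.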